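Cyclopropyl for isopropyl on the piperazine of compound 2

The source may report more compounds than this note shows. Statements on the series, on what has been measured and on what is new or still open speak of the compounds shown alone.

Of the compounds shown here, two sharing one core have been measured in an ADME assay on microsomes from liver (Homo sapiens) for metabolic stability, read by LC-MS, with a stated time of 10 min, tested at 0.5 uM; on this read-out lower numbers stand for a less stable compound and higher numbers for a more stable compound. Compound 1 `c1ccc2c(c1)CN[C@@H](CN(CCC1CCNCC1)[C@H]1CCCc3cccnc31)C2` gives 66% in this assay, and compound 2 `CC(C)N1CCN(CCCN(C[C@H]2Cc3ccccc3CN2)[C@H]2CCCc3cccnc32)CC1` gives 46%. Within the data shown here, the one recorded step between them, a number 20 percentage points lower from compound 1 to compound 2 (beyond the scatter), comes with (4-isopropylpiperazin-1-yl)methyl in place of piperidin-4-yl on a saturated chain carbon, two bonds along the chain from an amine nitrogen. Among the measured compounds shown here, compound 2 thus stands lowest of the two numbers, with compound 1 as its only neighbour, higher by that step and beyond the scatter.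

Compound 3 `c1ccc2c(c1)CN[C@@H](CN(CCCN1CCN(C3CC3)CC1)[C@H]1CCCc3cccnc31)C2` differs from compound 2 by cyclopropyl in place of isopropyl on an amine nitrogen in a ring. For the measured compounds named here, no measured step bears on this change: the only step known, from compound 1 to compound 2, alters the whole chain end rather than the group on the ring nitrogen, so it offers no guide to the direction. Compound 3 is therefore expected to show a step of a number 4 percentage points higher from compound 2 to compound 3 (within the scatter), within the scatter. The estimate for compound 3 in this assay is 50%, with a range from 35% to 68%.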

Compound 3, percent of the compound remaining: 21%
Beside the measured number, compound 3's estimate is 29 percentage points above it; measured number outside the range, below it.
By their numbers in this assay, from the lowest: compound 3; then compound 2; then compound 1.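

In this assay the group on the ring nitrogen of the piperazine proves to carry weight on its own: isopropyl and cyclopropyl have the same count of heavy atoms, all carbon, yet the change gives a number 25 percentage points lower from compound 2 to compound 3 (beyond the scatter) and so differs from the earlier step, which altered the whole chain end. That chain-end replacement now reads differently according to the group it carries, with a number 45 percentage points lower from compound 1 to compound 3 (beyond the scatter) for the cyclopropyl form set against a number 20 percentage points lower from compound 1 to compound 2 (beyond the scatter) for the isopropyl form, so the earlier step cannot be read as a fixed effect of the chain end alone. Nothing in the available data explains why these two groups differ.

Among these compounds, only two groups have been seen on this nitrogen, so it remains open whether the lower number belongs to cyclopropyl in particular or would follow other replacements of isopropyl, such as methyl, tert-butyl or cyclobutyl. From the compounds shown here alone, it also remains open whether cyclopropyl would lower the number in the same way on the ring nitrogen of the piperidin-4-yl in compound 1, where the chain end is different.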